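Trimming a Methyl from the Amide Double Bond

This account rests on a few compounds, and the source may have more. Where it says the series, first, only, none or still open, it means among the compounds named here.

Compound 1 `C=C(C)C(=O)N(Cc1ccc(OC)c(O)c1)c1cc(OC)c(OC)c(OC)c1` gives 200 nM. Compound 2 `COc1cc(NCc2ccc(Br)cc2)cc(OC)c1OC` gives only a limit, > 80000 nM. Compound 3 `COc1ccc(CNc2cc(OC)c(OC)c(OC)c2)cc1F` gives 46200 nM.

In a functional assay on KYSE-450 cells (Homo sapiens) for inhibition, read by MTT assay, with a stated time of 48 h (a higher number here means a weaker inhibitor, a lower number a stronger inhibitor), compound 1 holds the lowest of the two numbers shown; the nearest, compound 3, sits far higher, well beyond the scatter. For compound 2 the assay reports no number, only (the limit of > 80000 nM in this assay, at which 1 of the 3 values shown sits). No two of these measured compounds differ in a single place, so nothing can be said about the cause of the gap between compound 1 and compound 3 beyond what their two values show.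

Compound 4 `C=CC(=O)N(Cc1ccc(OC)c(O)c1)c1cc(OC)c(OC)c(OC)c1` has not yet been measured in this assay. It is compound 1 with one change: hydrogen in place of methyl on a double-bonded chain carbon bound to a carbonyl carbon. Within the data shown here, nothing among the measured compounds tests this change, so no step beyond the scatter is expected; the step from compound 1 to compound 4 is estimated as a 1.3-fold lower number from compound 1 to compound 4 (0.12 log units; within the scatter). On that basis compound 4 is expected to give about 150 nM, within a range from 40 nM to 600 nM.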

Compound 4, half-maximal inhibitory concentration: 160 nM
The estimate for compound 4 lay 1.1-fold (0.03 log units) below the measured number; the range from low to high includes it.
By their numbers in this assay, from the lowest: compounds 4 and 1 (each within the scatter of the next); then compound 3. At a limit, above all of these: compound 2.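

Among these compounds, this is the first comparison that changes only one place. In this assay, hydrogen in place of methyl on a double-bonded chain carbon bound to a carbonyl carbon gives a 1.3-fold lower number from compound 1 to compound 4 (0.10 log units; within the scatter). At this place, then, the methyl can be removed without a step beyond the scatter, and the vinylcarbonyl group matches the (1-methylethenyl)carbonyl group in this read-out, though no measurement shown bears on why.

What the compounds shown leave open is how far this place accepts other groups, such as an ethyl group, a dimethylaminomethyl group or a carboxylic acid, on the same chain carbon. They also leave open whether the double bond matters at all, since a saturated propanoyl group is not among them.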